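The source may hold more compounds than are shown below. What is called first, only, known or untested is meant among the compounds shown, and "the series" means these compounds.

In a functional assay for agonist activity at follicle-stimulating hormone receptor (Homo sapiens), read by a luciferase reporter (on this read-out higher numbers stand for an effect only at larger amounts of compound and lower numbers for an effect already at smaller amounts), compound 2, `CCCCCCN1C(=O)[C@H](Cc2ccc(-c3cccc(CN(CCCC)C(=O)NC)c3)cc2)N(C)C(=O)[C@@H]1C`, gives 7.2 nM, the lowest of the two numbers in hand, while compound 1, `CCCCCCCCN1C(=O)[C@H](Cc2ccc(-c3cccc(CN(CCCC)C(C)=O)c3)cc2)N(C)C(=O)[C@@H]1C`, gives 14 nM; the gap between these two lies within the usual scatter, so the two cannot be told apart on these figures. Compound 3, `CCCCCCCCN1C(=O)[C@H](Cc2ccc(-c3cccc(CN(CCCC)C(=O)NC)c3)cc2)N(C)C(=O)[C@@H]1C`, has not yet been measured. It differs from compound 2 by ethyl in place of hydrogen on a saturated chain carbon, six bonds along the chain from an amide-type nitrogen in a ring, so that the chain of compound 3 matches that of compound 1 while the rest of compound 2 is kept. For the measured compounds named here, no step between measured compounds tests this chain change on its own: the only comparison available, compound 1 against compound 2, alters the chain and the amide-type group together and shows nothing beyond the scatter. The step of a 1.1-fold higher number from compound 2 to compound 3 (0.05 log units; within the scatter) is therefore expected to stay within the scatter, with no clear direction. The estimate for compound 3 in this assay is 8 nM, in a range from 3 nM to 20 nM.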

Compound 3, half-maximal effective concentration: 1.2 nM
For compound 3 the middle estimate is 6.7-fold (0.82 log units) above the measured one, and the stated range ends above it.
By their numbers in this assay, from the lowest: compound 3; then compounds 2 and 1 (each within the scatter of the next).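

In this assay there is a 6.0-fold lower number from compound 2 to compound 3 (0.78 log units; beyond the scatter) when ethyl replaces hydrogen on a saturated chain carbon, six bonds along the chain from an amide-type nitrogen in a ring, so this change alone moves the number beyond the scatter, which the earlier pair, differing in two places, could not show. For the compounds shown here, with the chain held the same, methylamino in place of methyl on a carbonyl carbon gives a 12-fold lower number from compound 1 to compound 3 (1.07 log units; beyond the scatter) and so also matters on its own, a separation that the earlier compounds did not allow. Nothing measured here accounts for either step.

The compounds shown leave open whether a longer chain such as decyl would lower the number further or raise it again. They also do not say how ethylamino or a plain amino group would compare with methylamino on the same carbonyl carbon.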